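This account rests on a few compounds, and the source may have more. Where it says the series, first, only, none or still open, it means among the compounds named here.

Three compounds share one core, an aminophenyl ring joined to a five-membered ring that carries a carbonyl, and they were tested in an assay on isolated protein for inhibition of Nitric oxide synthase, inducible (Homo sapiens), with a stated time of 30 min, tested at 1 mM; on this read-out lower numbers stand for less inhibition and higher numbers for more inhibition at the one concentration tested (going by the name of the read-out). Compound 1 `Nc1ccc(Cl)cc1C1=NN(C(=O)c2ccccc2)CC1`, with a phenyl group on the carbonyl carbon and a chloro substituent on its core, gives 17%. Compound 2 `COc1ccc(N)c(C2=NN(C(=O)C3CCC3)CC2)c1`, with a cyclobutyl group on the carbonyl carbon and a methoxy substituent on its core, gives 1.91%. Compound 3 `COc1ccc(N)c(C2=NN(C(=O)C3CCCCC3)CC2)c1`, with a cyclohexyl group in the same place, gives 13.3%. Compound 3 thus stands second highest of the three numbers: its value lies within the scatter of compound 1 and beyond the scatter of compound 2.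

The step of a number 11.4 percentage points higher from compound 2 to compound 3 (beyond the scatter) shows that enlarging the ring on the carbonyl carbon from four to six members brought a modest rise. Compound 4 `COc1ccc(N)c(C2=NN(C(=O)c3ccccc3)CC2)c1` differs from compound 3 in one place: phenyl in place of cyclohexyl on a carbonyl carbon. Among the compounds with values here, only the step from compound 2 to compound 3 touches this position, and it was modest, while compound 1 shows that a phenyl group here on a different core gives a number in the same low range. A step from compound 3 to compound 4 of a number 1.7 percentage points higher from compound 3 to compound 4 (within the scatter) is therefore expected, within the scatter. Compound 4 is estimated at 15%, in a range from 3% to 28%.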

Compound 4, a percentage reported as inhibition, at one concentration (the size of the read-out at that concentration, not a potency): 12.2%
For compound 4 the middle estimate is 2.8 percentage points above the measured one, within the range that was stated.
By their numbers in this assay, from the lowest: compound 2; then compounds 4, 3 and 1 (each within the scatter of the next).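

In this assay, replacing the six-membered non-aromatic ring on the carbonyl carbon with a six-membered aromatic ring of the same size, with phenyl in place of cyclohexyl, gives a number 1.1 percentage points lower from compound 3 to compound 4 (within the scatter), so this position does not distinguish the two rings, while the change from cyclobutyl gives a number 10.3 percentage points higher from compound 2 to compound 4 (beyond the scatter) and thus places both six-membered rings apart from the cyclobutyl of compound 2. Within the data shown here, with phenyl held on the carbonyl carbon, the first such comparison of the two core substituents, methoxy in place of chloro on an aromatic carbon gives a number 4.8 percentage points lower from compound 1 to compound 4 (within the scatter), so this pair does not separate them. No measurement is available to explain why these compounds give the numbers they do.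

The compounds shown leave open what an open chain such as pentyl, or a ring of intermediate size such as cyclopentyl, would give on the carbonyl carbon. They also leave open whether a ring carrying an amine or a carboxylic acid there would lift the number clear of the low range seen for compound 1, compound 3 and compound 4.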